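The source may report more compounds than this note shows. Statements on the series, on what has been measured and on what is new or still open speak of the compounds shown alone.

Measured so far:
Compound 1, `COC(=O)C1=C(C(C)C)NC(=O)NC1c1cccc([N+](=O)[O-])c1`, gives only a limit in an assay on HEK293 cells for antagonist activity at Voltage-dependent L-type calcium channel subunit alpha-1D (Rattus norvegicus), read by FLIPR; a lower number here means a stronger inhibitor, a higher number a weaker inhibitor: > 100000 nM.
Compound 2, `COC(=O)N1C(=O)N(C(=O)OC)C(c2cccc([N+](=O)[O-])c2)C(C(=O)OC(C)C)=C1C`, gives 5880 nM in this assay.
Compound 3, `CCOC(=O)C1=C(N)OC(C)=C(C(=O)OC)C1c1cccc([N+](=O)[O-])c1`, gives 2720 nM in this assay.

Compound 3 holds the lowest of the two actual numbers: compound 2 sits a distance above it that lies beyond the usual scatter of this assay, and compound 1 contributes only a limit, so it cannot be ranked. For compound 1 that limit is the limit of > 100000 nM in this assay, at which 1 of the 3 values shown sits.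

Compound 4, `COC(=O)C1=C(C)OC(N)=C(C(=O)OC(C)C)C1c1cccc([N+](=O)[O-])c1`, has not yet been measured. It differs from compound 3 in one place: methyl in place of hydrogen on a saturated chain carbon bound to an oxygen next to a carbonyl group and a saturated chain carbon. Read one bond further out, an ethoxycarbonyl group becomes an isopropoxycarbonyl group; the rest of the molecule is unchanged. Among the measured compounds shown here, no measured pair shows the effect of this change directly, so the size of the step from compound 3 to compound 4 cannot be read from the data. A change this small is expected to move the number little, most likely within the scatter or slightly toward a stronger inhibitor. The expected step is a 1.5-fold lower number from compound 3 to compound 4 (0.18 log units; within the scatter). Compound 4 is therefore estimated at 1800 nM in this assay, with a likely range from 500 nM to 6500 nM.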

Compound 4, half-maximal inhibitory concentration: 1820 nM
For compound 4 the middle estimate is 1.0-fold (0.00 log units) below the measured one; low and high end bracket the measured number.
By their numbers in this assay, from the lowest: compounds 4 and 3 (each within the scatter of the next); then compound 2. At a limit, above all of these: compound 1.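

Among the compounds shown here, compounds 3 and 4 are the only pair here that differ in one place, so this is the first direct reading of a single change in this assay. Turning the ethoxycarbonyl group into an isopropoxycarbonyl group gives a 1.5-fold lower number from compound 3 to compound 4 (0.17 log units; within the scatter), so one added methyl at this saturated chain carbon leaves the number where it was, as far as this assay can tell. No measurement shown here accounts for the size of this step.

The compounds shown leave open whether a longer chain, a benzyl group or a carboxylic acid at this place would move the number beyond the scatter. For the compounds shown here, they also leave open whether the same methyl would have so little effect on a different core, since no other pair isolates it.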